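Lengthening the chain on the amino member of the series

A few compounds are considered here, and "the series" means these few. Any claim that something is new, unique, unknown or untested is made for them only; others in the source may bear on it.

Values in a functional assay on HCT-116 cells (Homo sapiens) for antiproliferative activity, read by MTT assay, with a stated time of 48 h; a higher number here means a weaker inhibitor, a lower number a stronger inhibitor:
- compound 1 `CCCCCCC(CCO)n1cnc2c(Cl)ncnc21`: 11900 nM
- compound 2 `CCCCCCC(CCO)n1cnc2c(N(C)C)ncnc21`: > 50000 nM (a limit)
- compound 3 `CCCCCCC(CCO)n1cnc2c(N)ncnc21`: > 50000 nM (a limit)

Compound 3 stands at > 50000 nM, which is a limit and not a number. Only compound 1 has a measured number, and the other two compounds sit at the limit of > 50000 nM in this assay, at which 2 of the 3 values shown sit.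

Compound 4 `CCCCCCCCC(CCO)n1cnc2c(N)ncnc21` keeps the amino group of compound 3 and changes only the chain: ethyl in place of hydrogen on a saturated chain carbon, seven bonds along the chain from an aromatic nitrogen.

Three measured steps are available, all on the aromatic carbon. Dimethylamino in place of chloro gives an at least 4.2-fold higher number from compound 1 to compound 2 (0.62 log units; beyond the scatter). Amino in place of chloro gives an at least 4.2-fold higher number from compound 1 to compound 3 (0.62 log units; beyond the scatter). Amino in place of dimethylamino gives a step that the two limits leave unreadable from compound 2 to compound 3. None of them alters the chain, so they give no direct size for this change. They bear on it only indirectly, by showing that the amino group goes with the limit in this assay.

A small shift towards a lower number is the most that is expected, and the assay may well report a limit again. The expected change is an at least 1.2-fold lower number from compound 3 to compound 4 (0.09 log units; that floor lies within the scatter). For compound 4 the estimated value in this assay is 40000 nM, with an expected range from 15000 nM to 90000 nM.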

Compound 4, half-maximal inhibitory concentration: 11600 nM
For compound 4 the middle estimate is 3.4-fold (0.54 log units) above the measured one, and the stated range ends above it.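

In this assay, the chain proves to be a place where the read-out can move: ethyl in place of hydrogen on a saturated chain carbon, seven bonds along the chain from an aromatic nitrogen, gives an at least 4.3-fold lower number from compound 3 to compound 4 (0.63 log units; beyond the scatter). For the compounds shown here, the earlier compounds varied only the group on the aromatic carbon, so compound 4 supplies the first measured number for a member of the series carrying the amino group, and it shows that this group does not by itself hold a compound at the limit. The size of the step is only a floor, because compound 3 stands at a limit and not at a number: the limit of > 50000 nM in this assay, at which 2 of the 4 values shown sit.

Going by these compounds, it remains open whether a still longer chain at this place carries the shift further or whether the gain ends with this chain length. Also open, on these data alone, is whether the same lengthening gives a step of similar size on the chloro and dimethylamino members, or with a cyclic amine on the aromatic carbon.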